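The compounds below may be only part of what the source reports. "The series", "measured", "known", "first", "only" and "open" are said of these compounds alone.

In a physicochemical assay for lipophilicity, at pH 7.4 (a lower number here means a more polar compound, a higher number a more lipophilic compound), compound 1 `CC(C)CN(C1CCc2ccc(F)cc21)S(=O)(=O)c1ccc2c(c1)C(=O)CC(C1CCOCC1)O2` gives 4.03 and compound 3 `CCc1ccc(N(CC2CCC2)S(=O)(=O)c2ccc3c(c2)C(=O)CC(C2CCOCC2)O3)cc1` gives 4.1. These two numbers lie within the usual scatter of each other, so the measurements do not separate them. Compound 2 `CCc1ccc(N(CC(C)C)S(=O)(=O)c2ccc3cc(OCC4CCOCC4)c(C(=O)O)cc3c2)cc1` gives 1.77, well beyond the scatter from both. Compound 1 therefore sits at the upper end of this small set, level with compound 3.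

The next compound to be measured is compound 4 `CC(C)CN(c1ccc(C#N)cc1)S(=O)(=O)c1ccc2c(c1)C(=O)CC(C1CCOCC1)O2`. It keeps the core of compound 1 and changes one group, with 4-cyanophenyl in place of 6-fluoro-2,3-dihydro-1H-inden-1-yl on a sulfonamide nitrogen. The group that enters is the smaller of the two, and it brings a hydrogen-bond acceptor that the group leaving does not have.

Among the compounds with values here, none of the measured compounds differ from each other in only one place, so no measured step can serve as a guide to the size of this one. The forecast is therefore a judgement based on the structural change alone. A moderate fall in this assay is expected, probably just beyond the scatter. The estimated step is a number 0.63 log units lower from compound 1 to compound 4 (beyond the scatter). For compound 4 the estimate is 3.4, with an expected range from 2.9 to 3.9.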

Compound 4, distribution coefficient: 3.16
Estimate against measurement, compound 4: 0.24 log units above; low and high end bracket the measured number.
By their numbers in this assay, from the lowest: compound 2; then compound 4; then compounds 1 and 3 (each within the scatter of the next).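

Within the data shown here, this is the first step in the set that changes only one place, and it shows that the group on this sulfonamide nitrogen can move the reading in this assay on its own: with the core of compound 1 and the saturated chain kept, 4-cyanophenyl in place of 6-fluoro-2,3-dihydro-1H-inden-1-yl gives a number 0.87 log units lower from compound 1 to compound 4 (beyond the scatter) in a single change. That one change does several things at once, since it takes away the five-membered non-aromatic ring and the fluorine, and brings in a nitrile with its hydrogen-bond acceptor, leaving fewer heavy atoms in the group on this nitrogen. No measurement here bears on why the number moved, so the step stays a description of what was seen.

Which of those differences carries the step stays open, and a plain phenyl or a 4-aminophenyl on the same sulfonamide nitrogen would help to pull them apart. Compound 2 and compound 3 differ from the others in more than one place, so steps to them cannot be read, and whether this change would behave alike with a different chain on the nitrogen also remains unanswered.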